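The source may hold more compounds than are shown below. What is called first, only, known or untested is meant among the compounds shown, and "the series" means these compounds.

Compound 1 `COc1ccc(C(=O)/C=C/c2ccc(OCc3cn(Cc4ccccc4Br)nn3)cc2)cc1` gives 52% in a functional assay on A549 cells (Homo sapiens) for inhibition, read by MTT assay, with a stated time of 48 h, tested at 10 uM (on this read-out lower numbers stand for less inhibition of growth and higher numbers for more inhibition of growth at the one concentration tested), and stands second highest of the three numbers recorded there. Compound 2 `COc1ccc(C(=O)/C=C/c2ccc(OCc3cn(Cc4ccc(Br)cc4)nn3)cc2)cc1` gives 50% and compound 3 `COc1ccc(C(=O)/C=C/c2ccc(OCc3cn(Cc4cccc(F)c4)nn3)cc2)cc1` gives 56% in this assay, and the steps of a number 2 percentage points lower from compound 1 to compound 2 (within the scatter), a number 4 percentage points higher from compound 1 to compound 3 (within the scatter) and a number 6 percentage points higher from compound 2 to compound 3 (within the scatter) all lie within the scatter. Compound 4 `O=C(/C=C/c1ccc(OCc2cn(Cc3ccccc3Br)nn2)cc1)c1ccc([N+](=O)[O-])cc1` differs from compound 1 at a different place on the shared core: nitro in place of methoxy on an aromatic carbon. Among the measured compounds shown here, none of the measured steps touches this group, so no step of known size bears directly on the change, and the steps that are known show no movement beyond the scatter. The step of no change at the digits printed from compound 1 to compound 4 (within the scatter) is therefore expected to stay within the scatter. The estimate for compound 4 is 52%, ranging from 35% to 70%.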

Compound 4, percent growth inhibition at one concentration: 42%
Estimate against measurement, compound 4: 10 percentage points above; measured number inside the range.
By their numbers in this assay, from the lowest: compounds 4, 2, 1 and 3 (each within the scatter of the next, the first and the last beyond it).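

In this assay, among the compounds shown here, the exchange of 4-methoxyphenyl for 4-nitrophenyl gives the first step at this aromatic carbon, a number 10 percentage points lower from compound 1 to compound 4 (within the scatter). It is the largest step listed, yet it stays within the scatter, so this one exchange shows no clear effect at a place the earlier compounds left unchanged. Nothing available bears on a cause for this step. The compounds shown leave open how an amine or a carboxylic acid at this place would read, and whether nitro in place of methoxy gives a step of similar size alongside the 4-bromophenyl of compound 2 or the 3-fluorophenyl of compound 3.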